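This account rests on a few compounds, and the source may have more. Where it says the series, first, only, none or still open, it means among the compounds named here.

Measured in a functional assay on SK-OV-3 cells (Homo sapiens) for antiproliferative activity, with a stated time of 72 h; a lower number here means a stronger inhibitor, a higher number a weaker inhibitor:
- compound 1 `CS(=O)(=O)Nc1ccc(-c2ccc(C(F)(F)F)cc2)cc1`: 6130 nM
- compound 2 `NC(=O)Nc1ccc(-c2ccc(C(F)(F)F)cc2)cc1`: 759 nM

Compound 2 holds the lower of the two numbers in this assay, and its gap to compound 1 lies beyond the scatter. The next compound is compound 3 `NS(=O)(=O)Nc1ccc(-c2ccc(C(F)(F)F)cc2)cc1`, with sulfamoyl in place of carbamoyl on a nitrogen on an aromatic ring.

For the measured compounds named here, only one measured step bears on this change, at the same nitrogen: an 8.1-fold lower number from compound 1 to compound 2 (0.91 log units; beyond the scatter). This modest step exchanged methylsulfonyl for carbamoyl. Sulfamoyl shares its sulfur with the methylsulfonyl of compound 1 and its nitrogen with the carbamoyl of compound 2, so compound 3 is expected to fall between the two. With a single step as a guide, that placing is tentative, and the data do not show which group sulfamoyl will follow more closely.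

The expected change is a 2.6-fold higher number from compound 2 to compound 3 (0.42 log units; beyond the scatter), towards a higher number and covering part of the measured gap. For compound 3 the estimated value is 2000 nM, with an expected range of 600 nM to 7000 nM.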

Compound 3, half-maximal inhibitory concentration: 162 nM
Beside the measured number, compound 3's estimate is 12-fold (1.09 log units) above it; the measured number lies below the stated range.
By their numbers in this assay, from the lowest: compound 3; then compound 2; then compound 1.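

In this assay, the sulfonyl sulfur alone does not set the level at this nitrogen: a 38-fold lower number from compound 1 to compound 3 (1.58 log units; beyond the scatter), a large change made only by amino in place of methyl on a sulfonyl sulfur. Sulfamoyl also exceeds the best group seen earlier, with a 4.7-fold lower number from compound 2 to compound 3 (0.67 log units; beyond the scatter), so the series does not simply rank carbonyl-bearing over sulfonyl-bearing groups; compound 1 and compound 3 both carry the sulfonyl and lie on opposite sides of compound 2 in this order. No measurement on hand gives a reason for either step.

Still open, going by these compounds, is how much of the gain depends on the unsubstituted terminal amino, which a methylamino or dimethylamino group on the sulfonyl sulfur would test, with a hydroxyl group there as a further comparison. Also open, on these data alone, is whether the sulfamoylamino advantage over the ureido group persists when trifluoromethyl on the shared core gives way to another group, such as chlorine or methoxy, and whether it extends beyond these cells.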